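A few compounds are considered here, and "the series" means these few. Any claim that something is new, unique, unknown or untested is made for them only; others in the source may bear on it.

Compound 1 `COc1cccc(N2C(=O)COc3ccc(-c4cnc(Cl)c(NS(=O)(=O)c5ccc(F)cc5)c4)cc32)c1` gives > 40000 nM in a functional assay on HCT-116 cells (Homo sapiens) for antiproliferative activity, read by MTT assay, with a stated time of 72 h (on this read-out lower numbers stand for stronger inhibition and higher numbers for weaker inhibition), which is a limit of the assay and not a number.
Compound 2 `O=C1COc2ccc(-c3cnc(Cl)c(NS(=O)(=O)c4ccc(F)cc4)c3)cc2N1c1ccccc1` gives 39800 nM.
Compound 3 `O=C1COc2ccc(-c3cnc(Cl)c(NS(=O)(=O)c4ccc(F)cc4)c3)cc2N1c1ccc(F)cc1` gives 34200 nM.

Of the two numbers shown, compound 3 has the lowest, but its nearest neighbour is compound 2 and the step of a 1.2-fold lower number from compound 2 to compound 3 (0.07 log units; within the scatter) stays within the scatter, so the two cannot be ordered. The remaining value, that of compound 1, is a limit (the limit of > 40000 nM in this assay, at which 1 of the 3 values shown sits).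

Compound 4 `O=C1COc2ccc(-c3cnc(Cl)c(NS(=O)(=O)c4ccc(F)cc4)c3)cc2N1C1CCCCC1` differs from compound 3 in one place: cyclohexyl in place of 4-fluorophenyl on an amide-type nitrogen in a ring. The measured steps, a number no higher from compound 1 to compound 2 (the limit leaves the size open), an at least 1.1-fold lower number from compound 1 to compound 3 (0.06 log units; that floor lies within the scatter) and a 1.2-fold lower number from compound 2 to compound 3 (0.07 log units; within the scatter), all exchange small substituents on an aromatic ring carried by the amide-type nitrogen and all stay within the scatter or at a limit; none replaces that aromatic ring with a non-aromatic one, so none bears directly on the present change. For the measured compounds named here, with no measured step pointing in either direction, the number of compound 4 is expected to lie close to that of compound 3, a step of a 1.0-fold higher number from compound 3 to compound 4 (0.01 log units; within the scatter) that is not expected to exceed the scatter. Compound 4 is therefore estimated at 35000 nM, with a range from 15000 nM to 40000 nM.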

Compound 4, half-maximal inhibitory concentration: > 40000 nM
Compound 4: no number, only a limit (the forecaster's own chance of this, stated with the estimate: 40%); middle value at least 1.1-fold (0.05 log units) from the limit.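

Compound 4 is the only compound shown in which the group on the amide-type nitrogen in a ring is not aromatic, and its reading in this assay is a limit of the assay and not a number: the limit of > 40000 nM in this assay, at which 2 of the 4 values shown sit.

On these data alone, exchanging 4-fluorophenyl for cyclohexyl gives an at least 1.1-fold higher number from compound 3 to compound 4 (0.06 log units; that floor lies within the scatter), so this change brings no lower number, and the true size of the step stays unknown. Exchanging phenyl for cyclohexyl gives a number no lower from compound 2 to compound 4 (the limit leaves the size open). The step to compound 4 from compound 1 cannot be read.

As far as these compounds go, it remains open whether any group at this position can produce a step beyond the scatter. A small chain such as methyl, or an amine or a carboxylic acid carried on a longer chain, might behave differently from the six-membered carbon rings seen so far.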